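Phenyl to methylfuran on a cyanopyridine aorta series

The source may report more compounds than this note shows. Statements on the series, on what has been measured and on what is new or still open speak of the compounds shown alone.

Measured so far:
compound 1, `COc1nc(-c2nc3ccccc3n2C)cc(-c2ccccc2)c1C#N`, gives 300000 nM in a functional assay on aorta (Rattus norvegicus, strain Wister); on this read-out higher numbers stand for weaker inhibition and lower numbers for stronger inhibition.
compound 2, `CCOc1nc(-c2nc3ccccc3n2C)cc(-c2ccc(OC)cc2)c1C#N`, gives 436000 nM in this assay.

Compound 1 and compound 2 lie within the usual scatter of each other, so the two numbers describe one common level of weak inhibition rather than a difference between them. For the measured compounds named here, compound 1 thus stands at the level both compounds share, and no step between the two can be read from these values.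

Compound 3, `COc1nc(-c2nc3ccccc3n2C)cc(-c2ccc(C)o2)c1C#N`, has not yet been measured. Relative to compound 1 the change is 5-methylfuran-2-yl in place of phenyl on an aromatic carbon. No comparable exchange has been measured within this set, so nothing here says how far such a swap can move the read-out. With only the shared weak level of compound 1 and compound 2 as a guide, the expectation is that compound 3 stays near that level. The expected step is no change at the digits printed from compound 1 to compound 3 (within the scatter), which is no more than the scatter allows. Compound 3 is expected to give 300000 nM, with a range from 100000 nM to 900000 nM.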

Compound 3, half-maximal inhibitory concentration: 283000 nM
Compound 3: middle estimate off by 1.1-fold (0.03 log units), on the high side; the measured number falls inside the stated range.
By their numbers in this assay, from the lowest: compounds 3, 1 and 2 (each within the scatter of the next).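

For the compounds shown here, the step from phenyl to 5-methylfuran-2-yl is the first single-place exchange that can be read in this set, and in this assay it amounts to a 1.1-fold lower number from compound 1 to compound 3 (0.03 log units; within the scatter) on the shared core. At this position, ortho to a cyano group and opposite the ring nitrogen, a six-membered aromatic ring of carbon only and a five-membered aromatic ring with 1 hetero atom therefore cannot be told apart on this read-out, although the entering group brings a hydrogen-bond acceptor that phenyl lacks. No measurement shown here offers an explanation for this equal level of weak inhibition.

The compounds shown leave open whether anything placed at this position can move the read-out away from that weak level, for example a carboxylic acid, a dimethylamino group or a longer alkyl chain in place of the 5-methylfuran-2-yl ring. They also leave open whether the methyl group of the furan matters, which a plain furan-2-yl ring or a 5-methylthiophen-2-yl ring at the same carbon would address.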